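This account rests on a few compounds, and the source may have more. Where it says the series, first, only, none or still open, it means among the compounds named here.

Measured compounds:
- compound 1, `C#CCOc1ccc(-c2cc(-c3ccc(OCC#C)c(OC)c3)nc(C)n2)cc1`: 25000 nM
- compound 2, `C#CCOc1ccc(-c2cc(-c3ccc(OCC#C)c(OCC)c3)nc(-c3ccccc3)n2)cc1`: "not active" (no number reported)
- compound 3, `C#CCOc1ccc(-c2cc(-c3ccc(OCC#C)c(OCC)c3)nc(C)n2)cc1`: "not active" (no number reported)

Of the compounds shown here, three sharing one core have been tested in an assay on BTI-TN-5B1-4 cells for inhibition of Amine oxidase [flavin-containing] A (Homo sapiens), read by fluorescence and Amplex Red, using microsomes, with a stated time of 30 min; a lower number here means a stronger inhibitor, a higher number a weaker inhibitor. Compound 1 gives 25000 nM, a weak result. Compound 2 gives "not active" (no number reported) in this assay, so no number was obtained for it. Among the compounds with values here, compound 3 is reported as "not active" (no number reported) in this assay, and it is the only other compound without a number; where compound 3 stands relative to compound 1 or compound 2 therefore cannot be placed on a scale, beyond the fact that all three are weak or inactive.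

Compound 4, `C#CCOc1ccc(-c2cc(-c3ccc(OCC#C)c(OCC)c3)nc(N)n2)cc1`, has not yet been measured. It differs from compound 3 in one place: amino in place of methyl on an aromatic carbon. Within the data shown here, no measured step between two compounds exists here, so the size of this change can only be guessed. Given that compound 3 is inactive and compound 1 is weak, the expectation is that the step from compound 3 to compound 4 in this assay stays within the scatter or brings at most a small gain, and compound 4 may again come back without a number.

Compound 4 is expected to give around 30000 nM in this assay, with a likely range from 8000 nM to 100000 nM.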

Compound 4, half-maximal inhibitory concentration: "not active" (no number reported)
Nothing numeric was reported for compound 4, and the estimate cannot be compared.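

In this assay, within the data shown here, compound 3 and compound 4 are both reported as not active, without a number, so no step from methyl to amino can be read between them. No supporting evidence bears on this result. The compounds shown leave open whether this exchange affects inhibition at all.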